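The compounds below may be only part of what the source reports. "The series", "measured", "known", "first", "only" and "open" are said of these compounds alone.

In an ADME assay on a cell-free system (plasma, Homo sapiens) for protein binding, three compounds sharing one core have been measured. Compound 1 `O=C(O)CCn1c(=O)oc2cc(OCC3CCC3)c(Cl)cc21` gives 98.1%, compound 2 `C[C@@H](Oc1cc2oc(=O)n(CCC(=O)O)c2cc1Cl)c1cccnn1` gives 68.1%, and compound 3 `C[C@@H](Oc1cc2oc(=O)n(CCC(=O)O)c2cc1Cl)c1ccc(Cl)cn1` gives 99%. The values of compound 1 and compound 3 lie within the scatter of each other, and both stand far from compound 2.

Compound 4 `CCOc1cc2oc(=O)n(CCC(=O)O)c2cc1Cl` follows from compound 3 by a single change: hydrogen in place of 5-chloropyridin-2-yl on a saturated chain carbon bound to an oxygen on an aromatic ring and a saturated chain carbon. Hydrogen takes the place of 5-chloropyridin-2-yl on a saturated chain carbon bound to an oxygen on an aromatic ring and a saturated chain carbon.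

Going by the values given here, two measured steps bear on this. The closer one, a 32-fold lower unbound fraction from compound 2 to compound 3 (1.50 log units; beyond the scatter), swapped the group at this same place, while a 17-fold higher unbound fraction from compound 1 to compound 2 (1.23 log units; beyond the scatter) replaced the whole group on the oxygen. Both are large, so changes here can move this assay strongly, but neither step simply removes the group. Compound 2 suggests that losing 5-chloropyridin-2-yl can free much more compound, yet compound 1, with no aromatic ring in that group, still gives 98.1%. A sizeable move towards more free compound is therefore expected, though probably a smaller one than the step to compound 3. The estimated step is a 14-fold higher unbound fraction from compound 3 to compound 4 (1.15 log units; beyond the scatter). For compound 4 the expected value is 86%, with an estimated range from 65% to 96%.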

Compound 4, plasma protein binding: 95.8%
Compound 4: middle estimate off by 3.3-fold (0.52 log units) (unbound fraction), on the high side; the range from low to high includes it.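

In this assay, taking 5-chloropyridin-2-yl off this saturated chain carbon gives only a 4.2-fold higher unbound fraction from compound 3 to compound 4 (0.62 log units; beyond the scatter), so the very high binding of compound 3 does not rest on that aromatic group alone. The same replacement starting from pyridazin-3-yl runs the other way, with a 7.6-fold lower unbound fraction from compound 2 to compound 4 (0.88 log units; beyond the scatter), which places hydrogen between the two aromatic groups: relative to hydrogen at this place, 5-chloropyridin-2-yl lowers the unbound fraction and pyridazin-3-yl raises it. Methyl in place of cyclobutyl gives a 2.2-fold higher unbound fraction from compound 1 to compound 4 (0.34 log units; beyond the scatter), a modest step that shows the size of the group on this saturated chain carbon can still shift the read-out when no aromatic ring is involved.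

No measurement among those shown accounts for these directions or sizes. Going by these compounds, it also remains open where a plain phenyl or an amine at this place would fall relative to compound 2 and compound 3, and so whether the chlorine or the ring nitrogens of these aromatic groups set the direction of the step.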